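The source may hold more compounds than are shown below. What is called first, only, known or untested is meant among the compounds shown, and "the series" means these compounds.

Compound 1, `Nc1scc(CN2CCN(c3ccccc3F)CC2)c1C(=O)c1ccc(Cl)cc1`, gives -9.2% in a functional assay on CHO cells with adenosine receptor A1 (Homo sapiens) as the target, read by cAMP accumulation and immunoassay, with a stated time of 6 min, tested at 1 uM; a lower number here means a stronger effect, a higher number a weaker effect of the compound at the concentration tested.
Compound 2, `Nc1scc(CN2CCN(c3cccc(Cl)c3)CC2)c1C(=O)c1ccc(Cl)cc1`, gives -59% in this assay.

Of the two numbers in this assay, compound 2 has the lower one, with compound 1 the nearest and higher by a step beyond the scatter. Going by the values given here, the single measured step, a number 49.8 percentage points lower from compound 1 to compound 2 (beyond the scatter), is the only guide available, and it concerns a different change on the same ring than the one considered here.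

Compound 3, `Nc1scc(CN2CCN(c3cc(Cl)ccc3Cl)CC2)c1C(=O)c1ccc(Cl)cc1`, has not yet been measured in this assay. From compound 2 it differs by chloro in place of hydrogen on an aromatic carbon, placed ortho to a large group and para to a chloro group. Among the compounds with values here, no measured step adds a chloro in this way, so the step from compound 1 to compound 2 bears on it only indirectly, by showing that substitution of this phenyl ring can move the read-out a great deal. Because of a number 49.8 percentage points lower from compound 1 to compound 2 (beyond the scatter), a change of some size is plausible, but its direction is not established. The step is expected to be a number 14 percentage points higher from compound 2 to compound 3 (beyond the scatter), at the edge of the scatter. Compound 3 is therefore estimated at -45%, with a range from -80% to -5%.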

Compound 3, a percentage reported as activity, at one concentration (the size of the read-out at that concentration, not a potency): -42%
The estimate for compound 3 lay 3 percentage points below the measured number; measured number inside the range.
By their numbers in this assay, from the lowest: compound 2; then compound 3; then compound 1.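

Adding a chloro group to the 3-chlorophenyl ring of compound 2, on the aromatic carbon ortho to a large group and para to the existing chloro group, gives the first measured result for a change at this place (a number 17 percentage points higher from compound 2 to compound 3 (beyond the scatter)). The change is modest, and it shows that a second chloro group does not extend the shift seen with the first: in this assay, the 2,5-dichlorophenyl group of compound 3 falls between the 3-chlorophenyl group of compound 2 and the 2-fluorophenyl group of compound 1. Compound 3 nevertheless retains a large separation from the 2-fluorophenyl compound (a number 32.8 percentage points lower from compound 1 to compound 3 (beyond the scatter)), and no measured property of these groups is available to account for either step.

The compounds shown leave open whether the 2-chloro-substituted ring without the second chloro group would behave like compound 3, and whether a methoxy group, a methyl group or an amine at this place would move the read-out in the same direction. On these data alone, each number is also the size of the effect at one concentration, so how these compounds rank in potency remains open.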